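Notes on a hydroxy-for-methoxy step in compound 3

The compounds below may be only part of what the source reports. "The series", "measured", "known", "first", "only" and "open" are said of these compounds alone.

Measured compounds:
Compound 1 `O=C1c2ccccc2C(=O)N1CCCCN1CCc2ccc([N+](=O)[O-])cc2C1`, compound 1 gives 87.5 nM
Compound 2 `COc1cc2c(cc1OC)CN(CCCCNC(=O)c1ccc([N+](=O)[O-])cc1)CC2`, compound 2 gives 14700 nM
Compound 3 `COc1cccc(C(=O)NCCCCN2CCc3ccc([N+](=O)[O-])cc3C2)c1OC`, compound 3 gives 7870 nM

All three values come from an assay on membranes from liver for displacement of a labelled ligand from Sigma non-opioid intracellular receptor 1 (Rattus norvegicus), read by scintillation counting, with a stated time of 1.5 h; a lower number here means a stronger inhibitor, a higher number a weaker inhibitor. Compound 3 stands second highest of the three numbers; its value and that of compound 2 lie within the scatter of each other, so no order between them is claimed, while compound 1 sits at a far lower number, beyond the scatter. Compound 4 `COc1cccc(C(=O)NCCCCN2CCc3ccc([N+](=O)[O-])cc3C2)c1O` is not yet measured. It differs from compound 3 by hydrogen in place of methyl on an oxygen on an aromatic ring. Going by the values given here, no step between two measured compounds isolates this change, so nothing calibrates it. The expected step from compound 3 to compound 4 is a 1.0-fold higher number from compound 3 to compound 4 (0.01 log units; within the scatter), that is, none beyond the scatter. Compound 4 is estimated at 8000 nM, with an expected range from 2500 nM to 25000 nM.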

Compound 4, inhibition constant: 11200 nM
Estimate against measurement, compound 4: 1.4-fold (0.15 log units) below; the measured number falls inside the stated range.
By their numbers in this assay, from the lowest: compound 1; then compounds 3, 4 and 2 (each within the scatter of the next).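

In this assay the series now has its first calibrated step for methoxy to hydroxy on an aromatic ring (a 1.4-fold higher number from compound 3 to compound 4 (0.15 log units; within the scatter)), and it lies within the scatter. At this place, going from 2,3-dimethoxyphenyl to 2-hydroxy-3-methoxyphenyl therefore gives no readable change in the number. No measurement here bears on why the step is so small.

From the compounds shown here alone, whether an amine or a carboxylic acid at this oxygen-bearing place would give a step beyond the scatter stays open. So does whether methoxy to hydroxy reads the same on the core of compound 1.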